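A few compounds are considered here, and "the series" means these few. Any claim that something is new, unique, unknown or untested is made for them only; others in the source may bear on it.

Measured so far in an ADME assay on Vero cells (Chlorocebus sabaeus) for cytotoxicity, read by MTT assay, with a stated time of 72 h; on this read-out lower numbers stand for higher toxicity in this test and higher numbers for lower toxicity in this test:
- compound 1 `CCOc1ccc(C(=O)/C=C/c2ccc(C(=O)Nc3cccc(-c4cc(C(=O)OC)no4)c3)cc2)cc1`: > 40 ug/mL
- compound 2 `COC(=O)c1cc(-c2cccc(NC(=O)c3ccc(/C=C/C(=O)c4cccc(Cl)c4)cc3)c2)on1`: > 2.5 ug/mL
- compound 3 `COC(=O)c1cc(-c2cccc(NC(=O)c3ccc(/C=C/C(=O)c4cccnc4)cc3)c2)on1`: "not determined" (no result reported)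

Compound 3 stands nowhere on the numbers: for compound 3 no result was reported in this assay. The two further values of the series are limits, not numbers. Compound 1 reaches only the limit > 40 ug/mL in this assay. Compound 2 reaches only the limit > 2.5 ug/mL in this assay. Among the compounds with values here, the one measured step, a step that the two limits leave unreadable from compound 1 to compound 2, cannot be read because the limit of > 2.5 ug/mL in this assay, at which 1 of the 3 values shown sits, and the limit of > 40 ug/mL in this assay, at which 1 of the 3 values shown sits, are limits rather than numbers.

The step under consideration is 4-nitrophenyl in place of pyridin-3-yl on a carbonyl carbon, giving compound 4 `COC(=O)c1cc(-c2cccc(NC(=O)c3ccc(/C=C/C(=O)c4ccc([N+](=O)[O-])cc4)cc3)c2)on1`. The same change, cut one bond further out, reads (pyridin-3-yl)carbonyl to (4-nitrophenyl)carbonyl; the place is a carbonyl carbon whose other neighbour is a double-bonded chain carbon.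

Within the data shown here, no measured step bears on this change: the only step is unreadable, and compound 3 has no value. Nothing therefore supports any direction for the step in this assay beyond the scatter, and the expectation rests on the limits of compound 1 and compound 2 alone.

For compound 4 the estimated value in this assay is 40 ug/mL, expected between 12 ug/mL and 120 ug/mL, with a good chance that only a limit is reported.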

Compound 4, half-maximal cytotoxic concentration: > 20 ug/mL
Compound 4 gave a limit, no number; the forecaster's own chance of this, stated with the estimate: 60%; the middle value is on the limit's open side.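

In this assay compound 4 gives > 20 ug/mL, a limit and not a number. The steps to compound 4 from compound 1 and from compound 2 join limits only and cannot be read. The compounds shown leave open whether 4-ethoxyphenyl, 3-chlorophenyl and 4-nitrophenyl on the carbonyl carbon differ at all in this assay.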